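From hydroxy to propoxy on compound 3

A few compounds are considered here, and "the series" means these few. Any claim that something is new, unique, unknown or untested is made for them only; others in the source may bear on it.

Of the compounds shown here, three have been measured so far, and none of them yields a number. In an ADME assay on RAW264.7 cells (Mus musculus) for cytotoxicity, read by MTT assay, with a stated time of 24 h, in the presence of a further agent that is not named here (a higher number here means a weaker inhibitor, a lower number a stronger inhibitor), compound 1 `Cc1noc(CC2OC(=O)c3ccccc32)n1` gives > 40000 nM, which is a limit of the assay. Compound 2 `O=C1OC(Cc2nc(-c3ccc(-c4ccccc4)cc3)no2)c2ccccc21` gives > 40000 nM in this assay, and this too is a limit. Compound 3 `COc1cc(OC)c2c(c1)C(C(O)c1ccc(O)cc1)OC2=O` gives > 40000 nM in this assay, again a limit and not a number. The whole picture is therefore a single entry: the limit of > 40000 nM in this assay, at which 3 of the 3 values shown sit. Compound 3 thus stands level with the other two, and the data cannot rank the three.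

Compound 4 `CCCOc1ccc(C(O)C2OC(=O)c3c(OC)cc(OC)cc32)cc1` is compound 3 with propyl in place of hydrogen on an oxygen on an aromatic ring, or hydroxy to propoxy: propyl in place of hydrogen on an oxygen on an aromatic ring. Among the measured compounds shown here, no step between measured compounds is available to size this change. The expectation therefore rests on compound 3 with its limit of > 40000 nM and on the same limit for the two other compounds. The expected change is an at least 1.1-fold lower number from compound 3 to compound 4 (0.05 log units; that floor lies within the scatter), an estimated step that stays within the usual scatter, with any shift toward a lower number. A further limit is the more likely report. If a number does appear for compound 4, the estimate is 35000 nM, with an expected range from 12000 nM to 80000 nM.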

Compound 4, half-maximal inhibitory concentration: > 40000 nM
Compound 4 was reported as a limit; the forecaster's own chance of this, stated with the estimate: 70%; at least 1.1-fold (0.05 log units) between middle value and limit.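

In this assay compound 4 gives > 40000 nM, which is a limit and not a number. Among the compounds shown here, compound 3 also stands at a limit, and no step between compound 3 and compound 4 can be read. The compounds shown leave open whether propyl in place of hydrogen changes the value at all, and how the four rank: the limit of > 40000 nM in this assay, at which 4 of the 4 values shown sit.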